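This account rests on a few compounds, and the source may have more. Where it says the series, first, only, none or still open, it means among the compounds named here.

Within the data shown here, compound 1 `CC(=O)N1N=C(Nc2nc3ccc(C)cc3s2)CC1c1ccccc1` is the only compound here with a number in a functional assay on the whole organism (strain albino) with Mus musculus as the target, with a stated time of 0.5 h; on this read-out higher numbers stand for an effect only at larger amounts of compound and lower numbers for an effect already at smaller amounts: compound 1 gives 112 umol/kg. Compound 2 `CC(=O)N1N=C(Nc2nc3ccc(Cl)cc3s2)CC1c1ccccc1` has only "not determined" (no result reported) in this assay, so no comparison can be drawn from it. Compound 3 `CC(=O)N1N=C(Nc2nc3ccc(C)cc3s2)CC1c1ccc(O)cc1` differs from compound 1 in one place: hydroxy in place of hydrogen on an aromatic carbon. Among the measured compounds shown here, no measured pair shows what such a change does here, and compound 1 alone gives no direction. The step from compound 1 to compound 3 is expected to be small, a 1.2-fold higher number from compound 1 to compound 3 (0.06 log units; within the scatter), none beyond the usual scatter. Compound 3 is therefore estimated at 130 umol/kg, in a range from 50 umol/kg to 350 umol/kg.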

Compound 3, dose for half-maximal effect: 54.3 umol/kg
Compound 3: middle estimate off by 2.4-fold (0.38 log units), on the high side, within the range that was stated.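

Phenyl to 4-hydroxyphenyl is the first change here whose direction can be read: in this assay it gives a 2.1-fold lower number from compound 1 to compound 3 (0.31 log units; beyond the scatter) and so an effect already at a smaller amount of compound. The position therefore accepts a hydroxy group without loss, and the gain is modest and rests on this single pair. Nothing measured here explains why the number falls. From the compounds shown here alone, whether a methoxy group or an amine in the same place would act alike stays open. So does whether the hydroxy gain carries over to other cores.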